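The source may report more compounds than this note shows. Statements on the series, on what has been measured and on what is new or still open speak of the compounds shown alone.

Measured in a functional assay on HCT-15 cells (Homo sapiens) for cytotoxicity, read by colorimetric assay and MTT assay; a higher number here means a weaker inhibitor, a lower number a stronger inhibitor:
- compound 1 `CCOC(=O)Cn1c(=O)c(-c2ccc(OC)cc2)cc2c(OC)cc(OC)cc21`: 10000 nM
- compound 2 `COc1ccc(-c2cc3c(OC)cc(OC)cc3n(CCCC#N)c2=O)cc1`: 10000 nM
- compound 3 `COc1ccc(-c2cc3c(OC)cc(OC)cc3n(CC(=O)O)c2=O)cc1`: 10000 nM

Compound 3 stands level with compound 1 and compound 2 at the digits shown. The next change gives compound 4 `COc1ccc(-c2cc3c(OC)cc(OC)cc3n(CCC(=O)OCc3ccccc3)c2=O)cc1`: (benzyloxycarbonyl)methyl in place of carboxy on a saturated chain carbon bound to an aromatic nitrogen. Within the data shown here, three measured steps bear on it: no change at the digits printed from compound 1 to compound 3 (within the scatter), no change at the digits printed from compound 2 to compound 3 (within the scatter) and no change at the digits printed from compound 1 to compound 2 (within the scatter). All lie within the scatter. Among the measured compounds shown here, none of the measured compounds carries the entering six-membered aromatic ring, so this support is limited. No step beyond the scatter is therefore expected in this assay. The expected step is no change at the digits printed from compound 3 to compound 4 (within the scatter). The estimate for compound 4 is 10000 nM, with an expected range of 4000 nM to 20000 nM.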

Compound 4, half-maximal inhibitory concentration: 10000 nM
Compound 4: the middle estimate sits on the measured number at the digits printed, within the range that was stated.
By their numbers in this assay, from the lowest: compounds 1, 2, 3 and 4 (each within the scatter of the next).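

In this assay, (benzyloxycarbonyl)methyl puts a six-membered aromatic ring of carbon only on a saturated chain carbon bound to an aromatic nitrogen, and the read-out holds (no change at the digits printed from compound 3 to compound 4 (within the scatter)). The comparisons with the other two side chains agree (no change at the digits printed from compound 2 to compound 4 (within the scatter); no change at the digits printed from compound 1 to compound 4 (within the scatter)). This place therefore accepts a group of 11 heavy atoms with 0 hydrogen-bond donors without a readable shift from carboxy. No available evidence bears on this result. From the compounds shown here alone, whether an amine or an amide on this chain, or a substituent on the entering ring, would move the number remains open.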